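A few compounds are considered here, and "the series" means these few. Any claim that something is new, unique, unknown or untested is made for them only; others in the source may bear on it.

Measured compounds in a functional assay on HeLa cells (Homo sapiens) for inhibition, read by MTT assay; a lower number here means a stronger inhibitor, a higher number a weaker inhibitor:

Compound 1, `CCCCCCCCCCn1cc(/C=C/C(=O)c2ccc(NC(=O)CN3CCN(c4ccccc4)CC3)cc2)nn1`, gives 59100 nM.
Compound 2, `O=C(CN1CCN(c2ccccc2F)CC1)Nc1ccc(C(=O)/C=C/c2cn(Cc3ccc(Br)cc3)nn2)cc1`, gives 9120 nM.

Compound 2 stands at the lower of the two numbers in this assay; compound 1 gives the higher number, and the gap between the two lies beyond the usual scatter. Among the measured compounds shown here, the two compounds differ in more than one place, so no single step connects them and nothing can be read from the pair about any one change.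

Compound 3, `O=C(CN1CCN(c2ccccc2)CC1)Nc1ccc(C(=O)/C=C/c2cn(Cc3ccc(Br)cc3)nn2)cc1`, is not yet measured. It differs from compound 2 in one place: hydrogen in place of fluoro on an aromatic carbon, the fluoro leaving an aromatic carbon of a six-membered aromatic ring of carbon only and a hydrogen entering there. For the measured compounds named here, no measured pair shows this change on its own, so the expectation rests on the small size of the change alone: a single heavy atom leaves, no ring and no donor or acceptor is touched.

Starting from compound 2, the step of a 1.3-fold higher number from compound 2 to compound 3 (0.12 log units; within the scatter) is expected to stay within the scatter, with no clear direction. Compound 3 is estimated at 12000 nM, in the range 4000 nM to 35000 nM.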

Compound 3, half-maximal inhibitory concentration: 79700 nM
Beside the measured number, compound 3's estimate is 6.6-fold (0.82 log units) below it; the whole stated range lies below it.
By their numbers in this assay, from the lowest: compound 2; then compounds 1 and 3 (each within the scatter of the next).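

In this assay, among the compounds shown here, the change from 2-fluorophenyl to phenyl gives an 8.7-fold higher number from compound 2 to compound 3 (0.94 log units; beyond the scatter), the first reading of a single change at this place: one fluoro on an aromatic carbon, ortho to a large group, accounts for a step beyond the scatter, with the lower number on the fluorinated side. With phenyl held constant, 4-bromophenyl in place of nonyl on a saturated chain carbon bound to an aromatic nitrogen gives a 1.3-fold higher number from compound 1 to compound 3 (0.13 log units; within the scatter), which lies within the scatter, so this exchange does not separate the two compounds here. No measurement at hand offers a reason for the size of the fluoro step.

Open, on these data alone, is whether the step is specific to fluoro, or whether chloro, methyl, methoxy or a nitrile on the same aromatic carbon would also give a number on the side of compound 2. Also open, as far as these compounds go, is whether the fluoro step carries over to the nonyl series, and whether a shorter chain such as butyl or an unsubstituted benzyl group would stay within the scatter of the two groups compared so far.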